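From a lone number to a larger amide group

A few compounds are considered here, and "the series" means these few. Any claim that something is new, unique, unknown or untested is made for them only; others in the source may bear on it.

Values so far in a functional assay on PC-3 cells (Homo sapiens) for antiproliferative activity, read by MTT assay, with a stated time of 24 h (on this read-out lower numbers stand for stronger inhibition and higher numbers for weaker inhibition), are these
Compound 1 `CCn1c(C(=O)N[C@@H](C)C(=O)OC)ccc1C(CC)(CC)c1ccc(OCS(=O)(=O)c2ccccc2)c(C)c1` gives > 50000 nM (a limit, not a number)
Compound 2 `CCn1c(C(=O)N[C@H](C)C(=O)OC)ccc1C(CC)(CC)c1ccc(OCS(=O)(=O)c2ccccc2)c(C)c1` gives > 50000 nM (a limit, not a number)
Compound 3 `CCn1c(C(=O)NC(C)(C)CO)ccc1C(CC)(CC)c1ccc(OCS(=O)(=O)c2ccccc2)c(C)c1` gives 9850 nM (a number)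
Compound 4 `CCn1c(C(=O)N[C@H](CO)CCCO)ccc1C(CC)(CC)c1ccc(OCS(=O)(=O)c2ccccc2)c(C)c1` has no value yet

Going by the values given here, compound 3 gives 9850 nM and is the only compound here with an actual number. Compound 4 differs from it by a group of 7 heavy atoms (5 carbon, 2 oxygen; no ring) in place of a group of 5 heavy atoms (4 carbon, 1 oxygen; no ring), on an amide-type nitrogen and the entering group has no common name and one defined stereocentre.

Among the compounds with values here, two measured steps concern that same amide-type nitrogen. They are an at least 5.0-fold lower number from compound 1 to compound 3 (0.70 log units; beyond the scatter) and an at least 5.0-fold lower number from compound 2 to compound 3 (0.70 log units; beyond the scatter) and in both, 1-(hydroxymethyl)-1-methylethyl replaces 1-(methoxycarbonyl)ethyl. From the compounds shown here alone, each starts from a limit, so its full size stays open. The remaining step is a step that the two limits leave unreadable from compound 1 to compound 2 and gives no size to use.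

Neither readable step brings in the group found in compound 4. They show that a change on this nitrogen can move the read-out, but not which way this new group will move it. With compound 3 at 9850 nM as the anchor, no step beyond the scatter is expected. A return to a limit remains possible. The expected change is a 1.2-fold higher number from compound 3 to compound 4 (0.09 log units; within the scatter) and this is only an estimate. For compound 4 the estimated value is 12000 nM with an expected range from 3500 nM to 45000 nM in repeated measurements.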

Compound 4, half-maximal inhibitory concentration: 6810 nM
Compound 4: middle estimate off by 1.8-fold (0.25 log units), on the high side; low and high end bracket the measured number.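

In this assay, the larger group on the amide-type nitrogen gives a 1.4-fold lower number from compound 3 to compound 4 (0.16 log units; within the scatter), so compound 3 and compound 4 cannot be told apart, even though the entering group has 7 heavy atoms and 2 hydrogen-bond donors against 5 heavy atoms and 1 hydrogen-bond donor in the group that leaves. From the compounds shown here alone, measured against the 1-(methoxycarbonyl)ethyl group, the new group gives an at least 7.3-fold lower number from compound 1 to compound 4 (0.86 log units; beyond the scatter) and an at least 7.3-fold lower number from compound 2 to compound 4 (0.86 log units; beyond the scatter), and both steps start from a limit, so their full size stays open. Compound 3 is therefore no longer the only compound with an actual number, and among the four compounds shown, the two that sit at the limit are the two carrying 1-(methoxycarbonyl)ethyl.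

Going by these compounds, the step between compound 1 and compound 2 cannot be read, and whether configuration matters at this nitrogen stays open because both compounds sit at the same limit: the limit of > 50000 nM in this assay, at which 2 of the 4 values shown sit. Also open are the effect of the opposite configuration at the stereocentre of compound 4, and what a carboxylic acid or an amine at the end of a chain on this nitrogen would give.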